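This account rests on a few compounds, and the source may have more. Where it says the series, first, only, none or still open, it means among the compounds named here.

Compound 2, with the structure `CN(CCn1cc[n+](C)c1/C=N/O)S(C)(=O)=O`, carries a methylsulfonyl group on its amine nitrogen. Within the data shown here, in a physicochemical assay for lipophilicity (a higher number here means a more lipophilic compound, a lower number a more polar compound), compound 2 gives -3.31, the lower of the two numbers so far. Among the measured compounds shown here, its only measured neighbour is compound 1, `CN(C)CCn1cc[n+](C)c1/C=N/O`, which in this assay gives -3.06; the step of a number 0.25 log units lower from compound 1 to compound 2 (within the scatter) is within the scatter, so the two numbers cannot be told apart.

Compound 3, `CN(CCn1cc[n+](C)c1/C=N/O)S(=O)(=O)C(F)(F)F`, differs from compound 2 in one place: trifluoromethyl in place of methyl on a sulfonyl sulfur. For the measured compounds named here, no measured step touches the sulfonyl sulfur, and the one step available, from a methyl to a methylsulfonyl group on the amine nitrogen, concerns a different position and did not move the number beyond the scatter. Going by the values given here, there is therefore no direct precedent, only the sign that a single change to this part of the molecule has so far left the number roughly where it was.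

On that basis the step for compound 3 is expected to be small, a number 0.41 log units higher from compound 2 to compound 3 (beyond the scatter), and compound 3 is estimated to give -2.9, somewhere between -3.4 and -2.4.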

Compound 3, distribution coefficient: -1.5
Compound 3: the middle estimate sits 1.40 log units below what was measured; the measured number lies above the stated range.
By their numbers in this assay, from the lowest: compounds 2 and 1 (each within the scatter of the next); then compound 3.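

Among these compounds, until now, the only step was methylsulfonyl in place of methyl on an amine nitrogen, and it stayed within the scatter, so a single change to this part of the molecule could have seemed to matter little. The sulfonyl sulfur proves to be a sensitive place: in this assay, trifluoromethyl in place of methyl on a sulfonyl sulfur gives a number 1.81 log units higher from compound 2 to compound 3 (beyond the scatter) even though neither group carries a hydrogen-bond donor, a hydrogen-bond acceptor or a net charge. Nothing among the data shown gives a reason for a step of this size, which so far rests on this one pair of compounds.

On these data alone, it remains open whether the number would climb gradually or jump if the methyl on the sulfonyl sulfur gave way to fluoromethyl or difluoromethyl, and whether ethyl or phenyl in the same place would also move it beyond the scatter. As far as these compounds go, it is equally open whether trifluoromethyl has a step of similar size elsewhere on the molecule, for instance as a trifluoroacetyl group on the amine nitrogen.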